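The source may report more compounds than this note shows. Statements on the series, on what has been measured and on what is new or still open speak of the compounds shown alone.

Measured so far:
- compound 1, `COc1cccc(Cn2c(CN3CCN(C(=O)C4CC4)CC3)nc3ccccc32)c1`: 44.4%
- compound 2, `CCCCn1c(CN2CCN(C(=O)C3CC3)CC2)nc2ccccc21`: 18.2%

In an assay on isolated protein for inhibition of aldehyde dehydrogenase 1A1 (Homo sapiens), read by spectrophotometry, tested at 10 uM (on this read-out lower numbers stand for less inhibition and higher numbers for more inhibition at the one concentration tested (going by the name of the read-out)), compound 1 gives 44.4%, while compound 2 gives 18.2%. Compound 2 thus stands lowest of the two numbers; its nearest neighbour is compound 1, and the step of a number 26.2 percentage points lower from compound 1 to compound 2 (beyond the scatter) lies beyond the scatter.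

Compound 3, `O=C(C1CC1)N1CCN(Cc2nc3ccccc3n2Cc2cccc(F)c2)CC1`, is not yet measured. Its structure differs from compound 2 in one place: 3-fluorophenyl in place of propyl on a saturated chain carbon bound to an aromatic nitrogen. For the measured compounds named here, only one measured step bears on this. The step of a number 26.2 percentage points lower from compound 1 to compound 2 (beyond the scatter) shows what happened when a six-membered aromatic ring gave way to propyl at this very place: inhibition fell by a modest, clear amount. The change to compound 3 runs the other way, putting an aromatic ring back where propyl sat, though now carrying fluorine instead of methoxy. A rise of roughly the same size is therefore expected, a number 21.8 percentage points higher from compound 2 to compound 3 (beyond the scatter). For compound 3 the estimate in this assay is 40%, within 22% to 58%.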

Compound 3, a percentage reported as inhibition, at one concentration (the size of the read-out at that concentration, not a potency): 27.2%
The estimate for compound 3 lay 12.8 percentage points above the measured number, within the range that was stated.
By their numbers in this assay, from the lowest: compounds 2 and 3 (each within the scatter of the next); then compound 1.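

Replacing propyl with 3-fluorophenyl on a saturated chain carbon bound to an aromatic nitrogen gives a number 9 percentage points higher from compound 2 to compound 3 (within the scatter), so at this position an aromatic ring alone does not set the two compounds apart. The group carried on that ring does make a difference: fluoro in place of methoxy on an aromatic carbon gives a number 17.2 percentage points lower from compound 1 to compound 3 (beyond the scatter). For the compounds shown here, the earlier pair could not show this, since its single swap removed the ring and the methoxy group together. Nothing available explains why methoxy and fluoro differ in this way.

On these data alone, it remains open whether another group on the ring, such as ethoxy, hydroxyl or an amine, would behave like methoxy or like fluoro. Also open, as far as these compounds go, is how a longer chain, such as hexyl, would compare with propyl at this position.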